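The source may hold more compounds than are shown below. What is called first, only, known or untested is meant among the compounds shown, and "the series" means these compounds.

Going by the values given here, only two compounds have been measured so far in a functional assay on HCT-8 cells (Homo sapiens) for cytotoxicity; a lower number here means that less compound is needed, a higher number that more compound is needed for the effect. In that test, compound 1 `COC1=C(C)C(=O)/C(=C(O)/C=C/c2cccs2)C(=O)C1(C)C` gives 8.6 ug/mL and compound 2 `CCC1=C(OC)C(CC)(CC)C(=O)C(C(=O)/C=C/c2ccccc2)=C1O` gives 3.7 ug/mL. Compound 2 therefore holds the lower of the two numbers, and its gap to compound 1 lies beyond the usual scatter of repeated measurements. The two compounds differ in more than one place, so this gap cannot be tied to any single structural change.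

The next compound, compound 3 `CCC1=C(OC)C(CC)(CC)C(=O)C(C(=O)/C=C/c2ccc(CC)cc2)=C1O`, keeps everything in compound 2 except the phenyl group, which becomes 4-ethylphenyl: ethyl in place of hydrogen on an aromatic carbon. In words, this is ethyl in place of hydrogen on an aromatic carbon, para to a large group. Among the compounds with values here, no measured pair of compounds shows what this change does in this assay, so the expectation is a cautious one, with no step beyond the scatter and no favoured direction. The step of a 1.1-fold lower number from compound 2 to compound 3 (0.02 log units; within the scatter) is estimated to be small. In this assay the value expected for compound 3 is 3.5 ug/mL, within an estimated range of 1.5 ug/mL to 8 ug/mL.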

Compound 3, concentration for half-maximal effect: 8.5 ug/mL
For compound 3 the middle estimate is 2.4-fold (0.39 log units) below the measured one, and the stated range ends below it.
By their numbers in this assay, from the lowest: compound 2; then compounds 3 and 1 (each within the scatter of the next).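

In this assay, going by these compounds alone, ethyl in place of hydrogen on an aromatic carbon, para to a large group, gives a 2.3-fold higher number from compound 2 to compound 3 (0.36 log units; beyond the scatter) and thus supplies the first reading of a single structural change. It shows that this position is not indifferent to substitution: the change from phenyl to 4-ethylphenyl, with everything else held as in compound 2, moves the number beyond the usual scatter and in the direction of more compound being needed for the effect. No measurement shown here accounts for this step.

The compounds shown leave open whether this step is particular to ethyl or would also appear with methyl, with a longer chain such as butyl, or with an amine or a carboxylic acid on the same aromatic carbon. They also leave open whether ethyl would give a step of similar size on another carbon of the same six-membered aromatic ring, or when added to a compound that differs from compound 2 elsewhere.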